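Isopropyl on the amine chain and clearance in rat microsomes

The compounds below may be only part of what the source reports. "The series", "measured", "known", "first", "only" and "open" are said of these compounds alone.

Three compounds built on a shared core were measured in an ADME assay on liver (strain Wistar) for metabolic stability, with Liver microsome (Rattus norvegicus) as the target, read by LC-MS, using microsomes and NADPH, with a stated time of 15 min, tested at 1 uM; on this read-out higher numbers stand for fast clearance and lower numbers for slow clearance. Compound 1, `CCc1cc(-c2noc(-c3cc(C)cc(CN(C)C)c3)n2)cc(C)c1OC[C@@H](O)CNC(=O)CO`, reaches only a limit of the assay in this assay, namely > 1250 mL.min-1.g-1. Compound 2, `CCc1cc(-c2noc(-c3cc(C)cc(CN(C)CC(C)C)c3)n2)cc(C)c1OC[C@@H](O)CNC(=O)CO`, gives 20 mL.min-1.g-1 in this assay. Compound 3, `CCc1cc(-c2noc(-c3cc(C)c(CN(C)C)s3)n2)cc(C)c1OC[C@@H](O)CNC(=O)CO`, gives 1220 mL.min-1.g-1 in this assay.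

The change from compound 1 to compound 2 is isopropyl in place of hydrogen on a saturated chain carbon bound to an amine nitrogen, and it brings an at least 62-fold lower number from compound 1 to compound 2 (1.79 log units; beyond the scatter). The two cores differ as 5-((dimethylamino)methyl)-4-methylthiophen-2-yl in place of 3-((dimethylamino)methyl)-5-methylphenyl on an aromatic carbon, a change that gives an at least 1.0-fold lower number from compound 1 to compound 3 (0.01 log units; that floor lies within the scatter), so the two parent compounds sit at the fast end together; the value of compound 1 is only a limit, (the limit of > 1250 mL.min-1.g-1 in this assay, at which 1 of the 3 values shown sits), so the true gap between them is not known.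

Compound 4, `CCc1cc(-c2noc(-c3cc(C)c(CN(C)CC(C)C)s3)n2)cc(C)c1OC[C@@H](O)CNC(=O)CO`, is not yet measured. Among the compounds with values here, it differs from compound 3 by isopropyl in place of hydrogen on a saturated chain carbon bound to an amine nitrogen, which is the same change as the one from compound 1 to compound 2, at the same place. On compound 1 that change produced an at least 62-fold lower number from compound 1 to compound 2 (1.79 log units; beyond the scatter). Compound 3 starts from a number that matches the limit of compound 1 as far as that limit allows, so a step of comparable size is expected, namely a 49-fold lower number from compound 3 to compound 4 (1.69 log units; beyond the scatter). Within the data shown here, for compound 4 the expected value in this assay is therefore 25 mL.min-1.g-1, with a plausible range from 8 mL.min-1.g-1 to 90 mL.min-1.g-1, resting on the single measured step from compound 1 to compound 2 and on the closeness of compound 3 to compound 1.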

Compound 4, intrinsic clearance in microsomes in the Liver microsome assay: 28 mL.min-1.g-1
Compound 4: the middle estimate sits 1.1-fold (0.05 log units) below what was measured, within the range that was stated.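

In the Liver microsome assay compound 4 gives 28 mL.min-1.g-1 as its measured value. Carried to the core of compound 3, isopropyl in place of hydrogen on a saturated chain carbon bound to an amine nitrogen gives, in the Liver microsome assay, a 44-fold lower number from compound 3 to compound 4 (1.64 log units; beyond the scatter), so a large step in intrinsic clearance in microsomes appears on both cores shown: the same change on two cores in the Liver microsome assay, an at least 62-fold lower number (1.79 log units; beyond the scatter) from compound 1 to compound 2 and a 44-fold lower number (1.64 log units; beyond the scatter) from compound 3 to compound 4; the limit leaves it open whether they differ

The value of compound 1 is only a limit of the assay, so its step is a floor and the two steps cannot be set against each other in size: the limit of > 1250 mL.min-1.g-1 in the Liver microsome assay, at which 1 of the 4 values shown sits.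

In a physicochemical assay for lipophilicity, in phosphate buffer, at pH 7 (on this read-out lower numbers stand for lower lipophilicity and higher numbers for higher lipophilicity), compound 3 gives 3.2 as its measured value. In the physicochemical assay the value of compound 4 is > 4.1 and is only a limit of the assay. Within the data shown here, only two cores carry the change, so nothing follows for any other core, and in the physicochemical assay the same change brings a number at least 0.90 log units higher from compound 3 to compound 4 (beyond the scatter), which means that on this pair the two shifts come together and cannot be told apart.

The compounds shown leave open whether the lower clearance is tied to the isobutyl(methyl)amino group itself or would also come with a shorter ethyl chain, a longer chain, or a cyclic amine such as pyrrolidine or morpholine. They also leave open whether a hydroxyl group or a carboxylic acid on that chain would keep the clearance of compound 4 while changing the distribution coefficient.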